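Methoxy removal in two pairs of indole-bearing compounds

The source may report more compounds than this note shows. Statements on the series, on what has been measured and on what is new or still open speak of the compounds shown alone.

Compound 1 `Cc1[nH]c2ccccc2c1C1=C(Br)C(=O)C(c2c(C)[nH]c3ccccc23)=C(Br)C1=O`: 7 ug/mL
Compound 2 `COc1ccc2[nH]c(C)c(C3=C(Br)C(=O)C(c4c(C)[nH]c5ccccc45)=C(Br)C3=O)c2c1`: only a limit, > 25 ug/mL
Compound 3 `COc1ccc2[nH]c(C)c(C3=C(Br)C(=O)C(Br)=C(c4c(-c5ccccc5)[nH]c5ccccc45)C3=O)c2c1`: 3.38 ug/mL

The three were tested in a functional assay on MCF7 cells (Homo sapiens) for antiproliferative activity, read by CCK-8 assay, with a stated time of 48 h; a higher number here means a weaker inhibitor, a lower number a stronger inhibitor. Compound 2 reports only a limit of this assay. Compound 1 gives a number, and the step of an at least 3.5-fold lower number from compound 2 to compound 1 (0.55 log units; beyond the scatter) is stated as a bound because compound 2 sits at the limit of > 25 ug/mL in this assay, at which 1 of the 3 values shown sits. The change is hydrogen in place of methoxy on an aromatic carbon. Compound 3 gives the lower of the two numbers, with compound 1 beyond scatter above it; how the cores of compound 2 and compound 3 differ is not broken down here.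

Compound 4 `Cc1[nH]c2ccccc2c1C1=C(Br)C(=O)C(Br)=C(c2c(-c3ccccc3)[nH]c3ccccc23)C1=O` differs from compound 3 by hydrogen in place of methoxy on an aromatic carbon, the same change. Compound 4 is expected near 1.5 ug/mL, between 0.5 ug/mL and 5 ug/mL. The expected step of a 2.3-fold lower number from compound 3 to compound 4 (0.35 log units; beyond the scatter) rests on an at least 3.5-fold lower number from compound 2 to compound 1 (0.55 log units; beyond the scatter).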

Compound 4, half-maximal inhibitory concentration: 3.02 ug/mL
Compound 4: middle estimate off by 2.0-fold (0.30 log units), on the low side; low and high end bracket the measured number.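

In this assay, the new step is a 1.1-fold lower number from compound 3 to compound 4 (0.05 log units; within the scatter), so on this core, replacing methoxy with hydrogen leaves the number within the scatter, and the step does not match the one seen on the other core: the same change on two cores in this assay, an at least 3.5-fold lower number (0.55 log units; beyond the scatter) from compound 2 to compound 1 and a 1.1-fold lower number (0.05 log units; within the scatter) from compound 3 to compound 4, at least 3.1-fold (0.50 log units) apart, beyond the scatter of two such steps. The earlier step is only a bound, and compound 2 gives only a limit: the limit of > 25 ug/mL in this assay, at which 1 of the 4 values shown sits. The change therefore cannot be assumed to carry over in size from one core to another in this series, but two pairs do not show which feature of the cores accounts for the gap.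

From the compounds shown here alone, it remains open whether a hydroxyl or a chlorine at the same place would differ between the two cores as well. Going by these compounds, it also remains open how a third core would respond to the same change.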